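The source may hold more compounds than are shown below. What is called first, only, known or untested is meant among the compounds shown, and "the series" means these compounds.

compound 1 `CCCCCC(CCO)n1c(Br)nc2c(Cl)ncnc21`: 18300 nM
compound 2 `CCCCCCCCCC(CCO)n1cnc2c(Cl)ncnc21`: 890 nM

Both values come from a functional assay on HCT-116 cells (Homo sapiens) for antiproliferative activity, read by MTT assay, with a stated time of 48 h; a higher number here means a weaker inhibitor, a lower number a stronger inhibitor. Compound 2 has the lower number of the two, and the gap to compound 1 lies beyond the scatter. Compound 3 `CCCCCCCCCC(CCO)n1c(Br)nc2c(Cl)ncnc21` is compound 2 with a single change: bromo in place of hydrogen on an aromatic carbon. Compound 1 also carries bromo at that place, but its chain differs from that of compound 2 as well, so the two values cannot show what bromo alone does. A modest weakening is therefore expected, an estimated 2.0-fold higher number from compound 2 to compound 3 (0.31 log units; beyond the scatter). For compound 3 the estimated value is 1800 nM, with a range of 500 nM to 6500 nM.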

Compound 3, half-maximal inhibitory concentration: 26900 nM
Estimate against measurement, compound 3: 15-fold (1.17 log units) below; the whole stated range lies below it.
By their numbers in this assay, from the lowest: compound 2; then compounds 1 and 3 (each within the scatter of the next).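

On this aromatic carbon between two ring nitrogen atoms, bromo is far from a neutral replacement for hydrogen: in this assay the change gives a 30-fold higher number from compound 2 to compound 3 (1.48 log units; beyond the scatter). With bromo in place, swapping hydrogen for butyl on the chain matters much less, giving a 1.5-fold higher number from compound 1 to compound 3 (0.17 log units; within the scatter), so compound 1 and compound 3 cannot be told apart here. Nothing measured here accounts for the large loss.

On these data alone, whether fluoro, methyl or an amine on this carbon would behave like hydrogen or like bromo remains open. So does the effect of the butyl change when hydrogen occupies this carbon.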